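A Shorter Side Chain on a Fatty Acid Receptor Agonist

The source may report more compounds than this note shows. Statements on the series, on what has been measured and on what is new or still open speak of the compounds shown alone.

Compound 1 `C/C(C#Cc1ccc(CCC(=O)O)c(F)c1)=C/CO` serves as the starting point. For the measured compounds named here, in a functional assay on 1321-N1 cells for agonist activity at Free fatty acid receptor 1 (Homo sapiens), read by calcium flux, with a stated time of 0.4 s (a lower number here means a smaller maximal response, a higher number a larger maximal response), compound 1 gives 105%, the highest of the two numbers measured so far. Compound 2 `CCCCCCCC#Cc1ccc(CCC(=O)O)cc1` gives 84% in this assay, a gap to compound 1 that lies beyond the usual scatter.

Compound 3 `C/C=C\C#Cc1ccc(CCC(=O)O)c(F)c1` is still unmeasured. It differs from compound 1 by prop-1-en-1-yl in place of 3-hydroxy-1-methylprop-1-en-1-yl on a triple-bonded carbon. Going by the values given here, no step between measured compounds covers this exchange, so the expectation rests on the two values alone. The step of a number 13 percentage points lower from compound 1 to compound 3 (beyond the scatter) is expected to be a modest fall that may still sit within the scatter. Compound 3 is estimated at 92%, with a range from 74% to 110%.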

Compound 3, largest response reached (reported as efficacy), in percent of the reference or control that the assay uses: 91%
Estimate against measurement, compound 3: 1 percentage points above, within the range that was stated.
By their numbers in this assay, from the lowest: compounds 2 and 3 (each within the scatter of the next); then compound 1.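

At this triple-bonded carbon, 3-hydroxy-1-methylprop-1-en-1-yl gives way to prop-1-en-1-yl, with no hydrogen-bond donor or acceptor in the entering group, and this assay records a modest fall that lies beyond the scatter (a number 14 percentage points lower from compound 1 to compound 3 (beyond the scatter)). A sizeable maximal response therefore remains without the hydroxy and methyl of the larger group. Nothing available explains this fall.

For the compounds shown here, the single exchange does not separate the loss of the hydroxy from that of the methyl. Going by these compounds, how an amine or a carboxylic acid at this place would compare remains open.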